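From Chlorophenyl to Pyrrolyl: What to Expect of Compound 3

A few compounds are considered here, and "the series" means these few. Any claim that something is new, unique, unknown or untested is made for them only; others in the source may bear on it.

Compound 1 `CC1=CC[C@H](C(C)(C)NC(=S)N/N=C/c2ccccc2Cl)CC1`: 19300 nM
Compound 2 `CC1=CC[C@H](C(C)(C)NC(=S)N/N=C/c2cccc(Cl)c2)CC1`: 9000 nM

Of the compounds shown here, two of a shared core have been measured in a functional assay on UACC-62 cells (Homo sapiens) for inhibition, read by sulforhodamine B assay, with a stated time of 48 h; a lower number here means a stronger inhibitor of growth, a higher number a weaker inhibitor of growth. Compound 1 gives 19300 nM and compound 2 gives 9000 nM. The single step between them, a 2.1-fold lower number from compound 1 to compound 2 (0.33 log units; beyond the scatter), is modest yet beyond the scatter, so compound 2 stands as the lower of the two numbers shown and thus as the stronger inhibitor of growth of the pair.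

Compound 3 `CC1=CC[C@H](C(C)(C)NC(=S)N/N=C/c2ccc[nH]2)CC1` has not yet been measured. It differs from compound 2 in one place: 1H-pyrrol-2-yl in place of 3-chlorophenyl on a carbon with a double bond to nitrogen. Going by the values given here, no measured step bears directly on this change; the only step known moved a chlorine substituent within the same aromatic ring and did not replace the ring, so it offers little guidance for an exchange of one aromatic ring for another. The expectation for compound 3 in this assay is therefore centred near the value of compound 2, with a wide range, and the step of a 1.3-fold higher number from compound 2 to compound 3 (0.12 log units; within the scatter) is expected to remain within the scatter. Compound 3 is estimated at 12000 nM, between 4000 nM and 40000 nM.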

Compound 3, concentration for 50% growth inhibition: 14800 nM
For compound 3 the middle estimate is 1.2-fold (0.09 log units) below the measured one; the measured number falls inside the stated range.
By their numbers in this assay, from the lowest: compounds 2, 3 and 1 (each within the scatter of the next, the first and the last beyond it).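

In this assay, going by these compounds alone, the place on a carbon with a double bond to nitrogen proves open to an exchange of the whole aromatic ring, where the earlier compounds showed only a chlorine moved within one ring: 1H-pyrrol-2-yl in place of 3-chlorophenyl gives a 1.6-fold higher number from compound 2 to compound 3 (0.22 log units; within the scatter) and, read against the other chlorinated compound, a 1.3-fold lower number from compound 1 to compound 3 (0.12 log units; within the scatter) as its counterpart. The five-membered aromatic ring with 1 hetero atom and 1 hydrogen-bond donor, carrying no chlorine, thus lies within the scatter of both chlorophenyl compounds, even though those two stand beyond the scatter of each other. Among these three compounds, then, only the shift of the chlorine separates two numbers, and the change of ring separates neither pair; nothing available explains this result.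

What the compounds shown leave open is whether the hydrogen on the pyrrole nitrogen matters at this place, which 1-methyl-1H-pyrrol-2-yl or furan-2-yl would address. They also do not tell how other aromatic rings such as pyridin-2-yl or thiophen-2-yl, or a phenyl ring bearing an amine or a carboxylic acid, would read in this assay at this same place.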